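From fluoro to methoxy on compound 3

This account rests on a few compounds, and the source may have more. Where it says the series, first, only, none or still open, it means among the compounds named here.

Within the data shown here, in a functional assay on A549 cells (Homo sapiens) for inhibition, read by MTT assay, with a stated time of 48 h (a higher number here means a weaker inhibitor of growth, a lower number a stronger inhibitor of growth), compound 3 `COc1ccc2c(c1)c(C1CC(c3ccc(F)cc3)=NN1C(=O)c1ccc(OC)nc1)cn2C` gives 710 nM, the lower of the two exact numbers measured so far. Compound 1 `COc1ccc(C2=NN(C(=O)c3cccnc3)C(c3cn(C)c4ccc(Br)cc34)C2)cc1OC` gives 2380 nM, a gap that lies beyond the usual scatter. Compound 2 `COc1cc(C2=NN(C(=O)c3cccnc3)C(c3cn(C)c4ccc(Br)cc34)C2)cc(OC)c1OC` reads > 10000 nM, which is a limit of the assay and not a number.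

Compound 4 `COc1ccc(C2=NN(C(=O)c3ccc(OC)nc3)C(c3cn(C)c4ccc(OC)cc34)C2)cc1` changes one group of compound 3 methoxy in place of fluoro on an aromatic carbon, turning 4-fluorophenyl into 4-methoxyphenyl.

Among the measured compounds shown here, only one measured step bears on this change. Methoxy in place of hydrogen on an aromatic carbon gives an at least 4.2-fold higher number from compound 1 to compound 2 (0.62 log units; beyond the scatter), a clear loss of growth inhibition. That step replaces hydrogen rather than fluoro, and its compounds differ from compound 3 elsewhere too, so it is only a loose guide.

The expected change is a modest one toward weaker inhibition, a 2.1-fold higher number from compound 3 to compound 4 (0.32 log units; beyond the scatter). For compound 4 the estimated value is 1500 nM, with an expected range of 450 nM to 5000 nM.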

Compound 4, concentration for 50% growth inhibition: 450 nM
Beside the measured number, compound 4's estimate is 3.3-fold (0.52 log units) above it; the measured number falls inside the stated range.
By their numbers in this assay, from the lowest: compounds 4 and 3 (each within the scatter of the next); then compound 1. At a limit, above all of these: compound 2.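

In this assay, turning 4-fluorophenyl into 4-methoxyphenyl gives a 1.6-fold lower number from compound 3 to compound 4 (0.20 log units; within the scatter) and so, on this aromatic carbon para to a large group, fluoro and methoxy cannot be told apart. Among these compounds, the one earlier step with an entering methoxy, an at least 4.2-fold higher number from compound 1 to compound 2 (0.62 log units; beyond the scatter), was a clear loss of growth inhibition, and that loss does not carry over to this change, so a methoxy is not harmful wherever it enters. No measurement shown gives a reason for this difference between the two steps.

The compounds shown leave open how an amine, a carboxylic acid or a longer chain would read in this same place. They also leave open whether the swap from fluoro to methoxy would read the same on the core of compound 1.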